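Triazole for chloro on the chloromethyl arm of compound 3

The compounds below may be only part of what the source reports. "The series", "measured", "known", "first", "only" and "open" are said of these compounds alone.

Measured in a functional assay on SW480 cells (Homo sapiens) for antiproliferative activity, read by MTT assay, with a stated time of 48 h; a lower number here means a stronger inhibitor, a higher number a weaker inhibitor:
compound 1 `CC(=O)OC/C1=C/C[C@](C)(CCC=C(C)C)/C=C/[C@@H](OC(=O)C=C(C)C)[C@](C)(OC(C)=O)/C=C/C1=O` gives 3520 nM
compound 2 `C=C1/C=C/C(=O)/C(CO)=C\C[C@](C)(CCC=C(C)C)/C=C/[C@H]1OC(=O)C=C(C)C` gives 2970 nM
compound 3 `CC(C)=CCC[C@]1(C)/C=C/[C@@H](OC(=O)C=C(C)C)[C@](C)(O)/C=C/C(=O)/C(CCl)=C\C1` gives 390 nM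

Compound 3 stands lowest of the three, and its gaps to compound 2 and to compound 1 are both beyond the scatter. Compound 4 `CC(C)=CCC[C@]1(C)/C=C/[C@@H](OC(=O)C=C(C)C)[C@](C)(O)/C=C/C(=O)/C(Cn2cc(CO)nn2)=C\C1` differs from compound 3 in one place: 4-(hydroxymethyl)-1H-1,2,3-triazol-1-yl in place of chloro on a saturated chain carbon bound to a double-bonded ring carbon. Within the data shown here, no measured pair in this set carries the same change, so the step is untested. Compounds 1 and 2, which lack the chloro, stand well above compound 3, and the entering group is far larger than the one leaving; the step is therefore expected to be upward, beyond the scatter, and for compound 4 it is estimated as a 6.4-fold higher number from compound 3 to compound 4 (0.81 log units; beyond the scatter). Compound 4 is expected to give about 2500 nM, within 600 nM to 10000 nM.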

Compound 4, half-maximal inhibitory concentration: 2870 nM
For compound 4 the middle estimate is 1.1-fold (0.06 log units) below the measured one; low and high end bracket the measured number.
By their numbers in this assay, from the lowest: compound 3; then compounds 4, 2 and 1 (each within the scatter of the next).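

Among these compounds, on a saturated chain carbon bound to a double-bonded ring carbon, this is the first single-place change: in this assay, 4-(hydroxymethyl)-1H-1,2,3-triazol-1-yl in place of chloro gives a 7.4-fold higher number from compound 3 to compound 4 (0.87 log units; beyond the scatter). The position is thus not indifferent to what it carries, and this substituent gives up the low number of compound 3. No measured evidence bears on the reason for the step.

Still open, on these data alone, is whether the step follows from the triazole ring or from its hydroxymethyl. Also open, as far as these compounds go, is whether bromo or an amine at this position would hold the number of compound 3.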